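Shortening the Ester Chain: From Compound 2 to Compound 3

The source may report more compounds than this note shows. Statements on the series, on what has been measured and on what is new or still open speak of the compounds shown alone.

compound 1 `COc1cc(/C=C/C(=O)OCCc2cccc(F)c2)cc(OC)c1O`: 230 nM
compound 2 `COc1cc(/C=C/C(=O)OCCc2ccccc2C)cc(OC)c1O`: 240 nM

Of the compounds shown here, two share one core and have been measured in an assay on PMNL cells for inhibition of Polyunsaturated fatty acid 5-lipoxygenase (Homo sapiens), read by HPLC, with stated times of 5 min and 15 min; a higher number here means a weaker inhibitor, a lower number a stronger inhibitor. Compound 1 gives 230 nM. Compound 2 gives 240 nM. Among the compounds with values here, the one step between them, a 1.0-fold higher number from compound 1 to compound 2 (0.02 log units; within the scatter), shows that exchanging one aromatic ring for another at this chain end changes nothing that can be read. Compound 2 holds the higher of the two numbers, yet the gap to compound 1 lies within the scatter, so the two count as equal.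

Compound 3 `CCCOC(=O)/C=C/c1cc(OC)c(O)c(OC)c1` has not been measured. Its difference from compound 2 is methyl in place of 2-methylphenyl on a saturated chain carbon, two bonds along the chain from an oxygen next to a carbonyl group. Within the data shown here, no measured step bears directly on this change: the step from compound 1 to compound 2 only swaps one aromatic ring for another and says nothing about removing the ring altogether. Without direct guidance, compound 3 is expected to reach a somewhat higher number than compound 2, by a 1.9-fold higher number from compound 2 to compound 3 (0.27 log units; within the scatter). For compound 3 the estimate is 450 nM, with a range from 150 nM to 1400 nM.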

Compound 3, half-maximal inhibitory concentration: 710 nM
Estimate against measurement, compound 3: 1.6-fold (0.20 log units) below; low and high end bracket the measured number.
By their numbers in this assay, from the lowest: compounds 1 and 2 (each within the scatter of the next); then compound 3.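

In this assay, this saturated chain carbon turns out not to be indifferent to what it carries: methyl in place of 2-methylphenyl gives a 3.0-fold higher number from compound 2 to compound 3 (0.47 log units; beyond the scatter), and methyl in place of 3-fluorophenyl gives a 3.1-fold higher number from compound 1 to compound 3 (0.49 log units; beyond the scatter), so the two routes to the same compound agree. Within the data shown here, the earlier pair showed only that one substituted aromatic ring could replace another with no readable change, whereas these steps show that losing the ring altogether, with 7 heavy atoms leaving and 1 entering, costs a modest but readable amount of inhibition. Nothing measured here explains why the number rises.

The change removes the aromatic ring and shortens the chain in a single move, so the compounds shown cannot separate the two effects. A plain hexyl chain or a cyclohexyl ring at this carbon would help tell whether an aromatic ring is needed or carbon atoms alone are enough, while an amine or a carboxylic acid there would test a different kind of group altogether.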